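Removing a Fluorine from a Serotonin Receptor Binder

The source may report more compounds than this note shows. Statements on the series, on what has been measured and on what is new or still open speak of the compounds shown alone.

For the measured compounds named here, in an assay on isolated protein for binding affinity to 5-hydroxytryptamine receptor 1D (Homo sapiens) (on this read-out lower numbers stand for stronger inhibition and higher numbers for weaker inhibition), compound 1 `Fc1ccc(-c2n[nH]cc2N2CCCNCC2)cc1` gives 2190 nM, which is the only plain number so far. Compound 2 `COc1cccc(-c2n[nH]cc2N2CCCNCC2)c1` shows > 10000 nM in this assay, and that is a limit of the measurement rather than a number. Compound 3 `c1ccc(-c2n[nH]cc2N2CCCNCC2)cc1` differs from compound 1 by hydrogen in place of fluoro on an aromatic carbon. Going by the values given here, no measured pair shows a change of this kind, so the step is expected to stay within the usual scatter, perhaps with a slight loss. Compound 3 is therefore expected to give about 3000 nM, between 1000 nM and 9000 nM, a step of a 1.4-fold higher number from compound 1 to compound 3 (0.14 log units; within the scatter).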

Compound 3, inhibition constant: > 10000 nM
Compound 3: no number, only a limit; the forecaster's own chance of this, stated with the estimate: 15%; middle value at least 3.3-fold (0.52 log units) away from the limit.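

On this aromatic carbon, para to a large group, the fluoro matters: replacing it with hydrogen gives an at least 4.5-fold higher number from compound 1 to compound 3 (0.65 log units; beyond the scatter) in this assay. For the compounds shown here, compound 1 therefore remains the only compound here with a plain number, and this single atom separates it from a limit. No step between compound 2 and compound 3 can be read, because neither value is a plain number: the limit of > 10000 nM in this assay, at which 2 of the 3 values shown sit.

From the compounds shown here alone, how far compound 3 lies past its limit stays open. So does whether chloro or an amine at this carbon would match or beat fluoro.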